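From 5-hydroxypentyl to 3,3-diethoxypropyl on the shared core

The compounds below may be only part of what the source reports. "The series", "measured", "known", "first", "only" and "open" are said of these compounds alone.

In a functional assay on MDA-MB-231 cells (Homo sapiens), read by wound healing assay, with a stated time of 24 h (a lower number here means a stronger inhibitor, a higher number a weaker inhibitor), compound 2 (`CC(C)=CCC[C@H](C)c1ccc(C)c(CNCCCCCO)c1O`) reads > 20000 nM, which is a limit and not a number. Compound 1 (`CC(C)=CCC[C@H](C)c1ccc(C)c(CNCCO)c1O`) also gives only a limit, > 20000 nM. Among the measured compounds shown here, the one numerical reading comes from compound 3 (`CC(C)=CCC[C@H](C)c1ccc(C)c2c1OCN(CCCCC(=O)O)C2`) at 29900 nM, and that compound differs from the other two in more than one place. Taken together, the series shows (the limit of > 20000 nM in this assay, at which 2 of the 3 values shown sit).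

Compound 4 (`CCOC(CCNCc1c(C)ccc([C@@H](C)CCC=C(C)C)c1O)OCC`) is reached from compound 2 by a single change, (diethoxymethyl in place of 3-hydroxypropyl on a saturated chain carbon, two bonds along the chain from an amine nitrogen). It places diethoxymethyl in the stead of 3-hydroxypropyl on a saturated chain carbon, two bonds along the chain from an amine nitrogen. Cut one bond further out, this reads 5-hydroxypentyl to 3,3-diethoxypropyl.

For the measured compounds named here, the only measured step at this place is a step that the two limits leave unreadable from compound 1 to compound 2, so it offers no size to carry over. No step beyond the usual scatter can therefore be predicted, and no firm direction either. What is expected is a step that the limit leaves unreadable from compound 2 to compound 4. A further limit reading would be no surprise in this assay. The estimate for compound 4 is 25000 nM, with an expected range from 10000 nM to 50000 nM.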

Compound 4, half-maximal inhibitory concentration: > 20000 nM
Compound 4: only a limit was reported (the forecaster's own chance of this, stated with the estimate: 55%); the middle value lies beyond the limit too.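

Compound 4 reads > 20000 nM, which is a limit and not a number, so its steps from compound 1 and from compound 2 cannot be read. The compounds shown leave open whether changing the chain on the shared core alters the reading at all in this assay, and the values offer only this: the limit of > 20000 nM in this assay, at which 3 of the 4 values shown sit.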